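This account rests on a few compounds, and the source may have more. Where it says the series, first, only, none or still open, it means among the compounds named here.

- Compound 1 `COc1cc(N2CCC(CC(=O)N3CCOCC3)CC2)ccc1Nc1nc(NC2CCCCC2)c2nc[nH]c2n1`: 1650 ng.h/mL
- Compound 2 `COc1cc(N2CCC(CC(=O)N3CCN(C)CC3)CC2)ccc1Nc1nc(NC2CCCCC2)c2nc[nH]c2n1`: 547 ng.h/mL

In an ADME assay on the whole organism (plasma, strain CD-1) for pharmacokinetics, with Mus musculus as the target, at a dose of 10 mg/kg by the oral route (a lower number here means less compound in the circulation, a higher number more compound in the circulation at the dose given), compound 2 stands lower of the two measured compounds, at 547 ng.h/mL. Compound 3 `COc1cc(N2CCC(CC(=O)N3CCCC3)CC2)ccc1Nc1nc(NC2CCCCC2)c2nc[nH]c2n1` differs from it by one change: pyrrolidin-1-yl in place of 4-methylpiperazin-1-yl on a carbonyl carbon. Pyrrolidin-1-yl thus takes the place of 4-methylpiperazin-1-yl on a carbonyl carbon. Going by the values given here, one measured step bears on this: a 3.0-fold lower number from compound 1 to compound 2 (0.48 log units; beyond the scatter), on entry of that same 4-methylpiperazin-1-yl group. Among the compounds with values here, no measured compound carries pyrrolidin-1-yl, so the evidence is indirect. Removing 4-methylpiperazin-1-yl is expected to bring a rise of similar size, and the estimate is a 2.2-fold higher number from compound 2 to compound 3 (0.34 log units; beyond the scatter). For compound 3 the expected value is 1200 ng.h/mL, within an estimated range of 450 ng.h/mL to 3200 ng.h/mL.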

Compound 3, area under the concentration-time curve: 1770 ng.h/mL
Estimate against measurement, compound 3: 1.5-fold (0.17 log units) below; the range from low to high includes it.
By their numbers in this assay, from the lowest: compound 2; then compounds 1 and 3 (each within the scatter of the next).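

In this assay the change to pyrrolidin-1-yl on the carbonyl carbon gives a 3.2-fold higher number from compound 2 to compound 3 (0.51 log units; beyond the scatter) and so reverses the fall seen with 4-methylpiperazin-1-yl. Set against morpholin-4-yl, the same group gives a 1.1-fold higher number from compound 1 to compound 3 (0.03 log units; within the scatter) and cannot be told apart from it. Among these three compounds, only compound 2 stands apart at this position.

From the compounds shown here alone, it remains open whether a piperidin-1-yl group, or a piperazin-1-yl group without the methyl, would read like compound 2 or like compound 1 and compound 3. Nothing available here accounts for the lower number of compound 2.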